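Swapping dimethylamino for diethylamino on compound 3

A few compounds are considered here, and "the series" means these few. Any claim that something is new, unique, unknown or untested is made for them only; others in the source may bear on it.

Three compounds have been read in a functional assay on U-937 cells (Homo sapiens) for antiproliferative activity, read by CCK-8 assay, with a stated time of 24 h (a lower number here means a stronger inhibitor, a higher number a weaker inhibitor), so far:

- Compound 1 (`CCN(CC)Cc1ccc2nc(NC(=O)N/N=C/c3ccccn3)sc2c1`) stands at 24800 nM as a measured number
- Compound 2 (`CC1CCN(Cc2ccc3nc(NC(=O)N/N=C/c4ccccn4)sc3c2)CC1`) stands at 21500 nM as a measured number
- Compound 3 (`CN(C)Cc1ccc(NC(=O)NN=C(c2ccccc2)c2ccccc2)cc1`) stands at > 25000 nM as a limit

On these figures compound 3 has no number, only the limit of > 25000 nM in this assay, at which 1 of the 3 values shown sits, to place it. Compound 4 (`CCN(CC)Cc1ccc(NC(=O)NN=C(c2ccccc2)c2ccccc2)cc1`) has not yet been measured. It differs from compound 3 in one place (diethylamino in place of dimethylamino on a saturated chain carbon bound to an aromatic carbon), with diethylamino in place of dimethylamino on a saturated chain carbon bound to an aromatic carbon.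

Among the compounds with values here, no measured step makes this exact exchange. The closest one is a 1.2-fold lower number from compound 1 to compound 2 (0.06 log units; within the scatter) and it starts from diethylamino at the same kind of place, though on a different core. Within the data shown here, it is the only evidence on such an exchange, and it is a single pair. No step beyond the scatter is expected in this assay because a 1.2-fold lower number from compound 1 to compound 2 (0.06 log units; within the scatter) is all there is to go on. Compound 4 is therefore expected to sit close to compound 3, and the reading may again be only a limit.

The estimated change is a step that the limit leaves unreadable from compound 3 to compound 4 and it carries no clear direction. For compound 4 the expected value is 28000 nM with an estimated range from 15000 nM to 55000 nM at this stage.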

Compound 4, half-maximal inhibitory concentration: > 25000 nM
Compound 4: only a limit was reported; the forecaster's own chance of this, stated with the estimate: 70%; the middle value does not contradict the limit.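

In this assay, within the data shown here, compound 3 and compound 4 each carry only a limit and not a number, so no step between them can be read: the limit of > 25000 nM in this assay, at which 2 of the 4 values shown sit.

The compounds shown leave open whether diethylamino in place of dimethylamino on a saturated chain carbon bound to an aromatic carbon changes the activity at all, and in which direction.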